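Pyrazole amides: bromopyridinyl for chloropyridinyl on the bromophenyl core

The compounds below may be only part of what the source reports. "The series", "measured", "known", "first", "only" and "open" are said of these compounds alone.

Compound 1 `Cc1ccc(-c2cc(NC(=O)c3cccnc3Cl)n[nH]2)cc1` gives 15800 nM in a functional assay on WM1361 cells (Homo sapiens) for antiproliferative activity, read by MTT assay, with a stated time of 48 h; a lower number here means a stronger inhibitor, a higher number a weaker inhibitor. Compound 2 `Cc1ccc(-c2cc(NC(=O)c3cncc(Br)c3)n[nH]2)cc1` gives 17900 nM in this assay, and compound 3 `O=C(Nc1cc(-c2ccc(Br)cc2)[nH]n1)c1cccnc1Cl` gives 18500 nM in this assay. The step of a 1.1-fold higher number from compound 1 to compound 2 (0.05 log units; within the scatter) comes from 5-bromopyridin-3-yl in place of 2-chloropyridin-3-yl on a carbonyl carbon. The step of a 1.2-fold higher number from compound 1 to compound 3 (0.07 log units; within the scatter) comes from bromo in place of methyl on an aromatic carbon, and this is also how the core of compound 3 differs from the core of compound 1. Compound 4 `O=C(Nc1cc(-c2ccc(Br)cc2)[nH]n1)c1cncc(Br)c1` is not yet measured; it differs from compound 3 by 5-bromopyridin-3-yl in place of 2-chloropyridin-3-yl on a carbonyl carbon, the same change made from compound 1 to compound 2, at the same place in both pairs. The step is expected to be a 1.1-fold higher number from compound 3 to compound 4 (0.03 log units; within the scatter), because the same change gave a 1.1-fold higher number from compound 1 to compound 2 (0.05 log units; within the scatter) on the other core. Compound 4 is estimated at 20000 nM in this assay, expected between 10000 nM and 40000 nM.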

Compound 4, half-maximal inhibitory concentration: 20300 nM
The estimate for compound 4 lay 1.0-fold (0.01 log units) below the measured number, within the range that was stated.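

In this assay, 5-bromopyridin-3-yl in place of 2-chloropyridin-3-yl on a carbonyl carbon gives a 1.1-fold higher number from compound 3 to compound 4 (0.04 log units; within the scatter), and the change reads alike on both cores: the same change on two cores in this assay, a 1.1-fold higher number (0.05 log units; within the scatter) from compound 1 to compound 2 and a 1.1-fold higher number (0.04 log units; within the scatter) from compound 3 to compound 4, 1.0-fold (0.01 log units) apart, within the scatter of two such steps. Bromo in place of methyl on an aromatic carbon gives a 1.1-fold higher number from compound 2 to compound 4 (0.05 log units; within the scatter), and this change also reads alike on both cores: the same change on two cores in this assay, a 1.2-fold higher number (0.07 log units; within the scatter) from compound 1 to compound 3 and a 1.1-fold higher number (0.05 log units; within the scatter) from compound 2 to compound 4, 1.0-fold (0.01 log units) apart, within the scatter of two such steps. Within the data shown here, all of these steps lie within the scatter, so the agreement shows only that neither change moves the number on these cores; it does not show that a change with a step beyond the scatter would carry over in the same way.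

Still open, going by these compounds, is what an amine or a carboxylic acid in place of the bromo on the aromatic carbon would do. On these data alone, whether any such group would move the number beyond the scatter also remains unknown.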